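Replacing trifluoromethyl with dimethylamino in compound 3

The source may report more compounds than this note shows. Statements on the series, on what has been measured and on what is new or still open speak of the compounds shown alone.

Compound 1 `COc1cc(-c2ccnc3cc(-c4ccc(C)c(C)c4)nn23)cc(OC)c1OC`: 26 nM
Compound 2 `COc1cc(-c2ccnc3cc(-c4ccc5cc[nH]c5c4)nn23)cc(OC)c1OC`: 23 nM
Compound 3 `COc1cc(-c2ccnc3cc(-c4ccc(C(F)(F)F)cc4)nn23)cc(OC)c1OC`: 2440 nM
Compound 4 `COc1cc(-c2ccnc3cc(-c4ccc(N(C)C)cc4)nn23)cc(OC)c1OC`: not yet measured

In a functional assay on MCF7 cells (Homo sapiens) for inhibition, read by CCK-8 assay, with a stated time of 48 h (on this read-out higher numbers stand for weaker inhibition and lower numbers for stronger inhibition), compound 3 stands highest of the three at 2440 nM, making it the weakest inhibitor measured so far. Compound 4 carries dimethylamino in place of trifluoromethyl on an aromatic carbon. Among the compounds with values here, no measured step makes this exchange directly. The closest evidence is a 94-fold higher number from compound 1 to compound 3 (1.97 log units; beyond the scatter) and a 110-fold higher number from compound 2 to compound 3 (2.03 log units; beyond the scatter), both large, whereas a 1.1-fold lower number from compound 1 to compound 2 (0.05 log units; within the scatter) stays within the scatter. Dimethylamino itself is untested, so only part of that gap is expected to be recovered. The expected step is a 20-fold lower number from compound 3 to compound 4 (1.31 log units; beyond the scatter), towards stronger inhibition. Compound 4 is estimated at 120 nM, with an expected range of 25 nM to 700 nM.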

Compound 4, half-maximal inhibitory concentration: 44 nM
Estimate against measurement, compound 4: 2.7-fold (0.44 log units) above; low and high end bracket the measured number.
By their numbers in this assay, from the lowest: compounds 2, 1 and 4 (each within the scatter of the next); then compound 3.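

In this assay, dimethylamino in place of trifluoromethyl gives a 55-fold lower number from compound 3 to compound 4 (1.74 log units; beyond the scatter), so the high number of compound 3 does not follow from having a single group at this position, but goes with trifluoromethyl there. The 4-(dimethylamino)phenyl group matches the two other groups, with a 1.9-fold higher number from compound 2 to compound 4 (0.28 log units; within the scatter) and a 1.7-fold higher number from compound 1 to compound 4 (0.23 log units; within the scatter), both within the scatter. Nothing available explains the difference between dimethylamino and trifluoromethyl.

On these data alone, whether a methoxy group, a primary amine or a carboxylic acid at this position would stay level with compound 4 or move towards compound 3 remains open.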